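Removing the Propyl Chain From an Inactive Core

The source may hold more compounds than are shown below. What is called first, only, known or untested is meant among the compounds shown, and "the series" means these compounds.

Compound 1 `C=CCn1ncc2c(C)nc(CCC)n2c1=S`: in a functional assay for inhibition, with Homo sapiens as the target (a higher number here means a weaker inhibitor, a lower number a stronger inhibitor), compound 1 gives > 48000 nM, which is a limit of the assay and not a number.
Compound 2 `Cc1ncn2c(O)nncc12`: in this assay compound 2 gives > 48000 nM, again only a limit.
Compound 3 `CCCc1nnc(O)n2c(C)ncc12`: in this assay compound 3 gives > 48000 nM, also a limit.

Compound 3 thus stands nowhere in particular on a scale of numbers: it sits at the same limit as the other two, as the limit of > 48000 nM in this assay, at which 3 of the 3 values shown sit, sums up. Among the measured compounds shown here, none of the three measured compounds differ from one another in a single place, so no measured step is available; all that can be said of compound 2 and compound 3 is that both show only the limit. Compound 4 `Cc1ncc2cnnc(O)n12` differs from compound 3 by hydrogen in place of propyl on an aromatic carbon. With every measured value resting at the limit, there is no basis for expecting a move in either direction, and the step from compound 3 to compound 4 is expected to be none beyond the scatter, that is a step that the limit leaves unreadable from compound 3 to compound 4. Compound 4 is therefore estimated at 70000 nM, within a range from 20000 nM to 300000 nM, and most likely it will again be reported only as a limit.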

Compound 4, half-maximal inhibitory concentration: > 48000 nM
Compound 4: no number, only a limit; the forecaster's own chance of this, stated with the estimate: 85%; the middle value is on the limit's open side.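

In this assay compound 4 gives > 48000 nM, which is a limit and not a number. Compound 3 rests at the same limit, so no step can be read between compound 3 and compound 4. The compounds shown leave open whether any structural change here affects inhibition, as all of them share one reading: the limit of > 48000 nM in this assay, at which 4 of the 4 values shown sit.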